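Trading 6-Chloro for 5-Chloro-1-benzothiophen-2-yl

A few compounds are considered here, and "the series" means these few. Any claim that something is new, unique, unknown or untested is made for them only; others in the source may bear on it.

Within the data shown here, in a physicochemical assay for lipophilicity (a lower number here means a more polar compound, a higher number a more lipophilic compound), compound 2 `CN(C)Cc1nccn1-c1ccc(N2CCC(NS(=O)(=O)c3cc4ccc(Cl)cc4s3)C2=O)c(F)c1` gives 2.58 and holds the higher of the two numbers so far, while compound 1 `CN(C)Cc1nccn1-c1ccc(N2CCC(NS(=O)(=O)c3ccc4c(Cl)c[nH]c4c3)C2=O)c(F)c1` gives 1.98 as the lower one. Among the measured compounds shown here, the only measured step is a number 0.60 log units higher from compound 1 to compound 2 (beyond the scatter) and it brought 6-chloro-1-benzothiophen-2-yl in place of 3-chloro-1H-indol-6-yl on a sulfonyl sulfur. Compound 3 `CN(C)Cc1nccn1-c1ccc(N2CCC(NS(=O)(=O)c3cc4cc(Cl)ccc4s3)C2=O)c(F)c1` is still unmeasured and differs from compound 2 in this way: 5-chloro-1-benzothiophen-2-yl in place of 6-chloro-1-benzothiophen-2-yl on a sulfonyl sulfur with 5-chloro-1-benzothiophen-2-yl in place of 6-chloro-1-benzothiophen-2-yl on a sulfonyl sulfur. The two have the same atoms, joined differently. For the measured compounds named here, the measured step swapped one group for a quite different one, so it is only a loose guide, and no measured pair shows a change like this. The expectation in this assay is therefore a number 0.02 log units higher from compound 2 to compound 3 (within the scatter) with no favoured direction and nothing beyond the scatter. Compound 3 is estimated at 2.6 with an expected range from 2.3 to 2.9 on this scale.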

Compound 3, distribution coefficient: 2.59
For compound 3 the middle estimate is 0.01 log units above the measured one, and the stated range covers the measured number.
By their numbers in this assay, from the lowest: compound 1; then compounds 2 and 3 (each within the scatter of the next).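

In this assay, among these compounds, 5-chloro-1-benzothiophen-2-yl in place of 6-chloro-1-benzothiophen-2-yl on the sulfonyl sulfur gives a number 0.01 log units higher from compound 2 to compound 3 (within the scatter), the first measured pair at this position in which the two groups are isomers, and here the exchange leaves the two numbers within the scatter. Set against the 3-chloro-1H-indol-6-yl group, the 5-chloro isomer gives a number 0.61 log units higher from compound 1 to compound 3 (beyond the scatter), so each of the two chloro-1-benzothiophen-2-yl groups stands beyond the scatter from compound 1. No evidence is available on what lies behind these numbers.

The compounds shown leave open whether this insensitivity extends to other replacements for the chlorine, such as a methoxy group or a nitrile. They also do not show what 1-benzothiophen-2-yl without any chlorine would give at this position.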